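This account rests on a few compounds, and the source may have more. Where it says the series, first, only, none or still open, it means among the compounds named here.

Compound 1 `CCCSc1nc(N)nc2c1ncn2/C=C1/CC1(CO)CO`. In an ADME assay on BCBL1 cells (Homo sapiens) for cytotoxicity, with a stated time of 7 days (on this read-out higher numbers stand for lower toxicity in this test and lower numbers for higher toxicity in this test), compound 1 gives > 20000 nM, which is a limit of the test and not a number.
Compound 2 `Nc1nc2c(ncn2/C=C2/CC2(CO)CO)c(=O)[nH]1`. In this assay compound 2 gives > 20000 nM, again a limit rather than a number.
Compound 3 `Nc1nc(N2CCCC2)c2ncn(/C=C3/CC3(CO)CO)c2n1`. In this assay compound 3 gives > 20000 nM, also a limit and not a number.

Compound 3 therefore stands nowhere definite on the scale: it sits, like the two others, at the limit of > 20000 nM in this assay, at which 3 of the 3 values shown sit. Compound 4 `CCCOc1nc(N)nc2c1ncn2/C=C1/CC1(CO)CO` has not been measured in this assay. It differs from compound 3 in one place: propoxy in place of pyrrolidin-1-yl on an aromatic carbon. Among the compounds with values here, the only measured step that touches the same position is a step that the two limits leave unreadable from compound 1 to compound 3, and the two limits leave its size unreadable, so no measured step gives a direction or size for the move to propoxy. Because of the limit of > 20000 nM in this assay, at which 3 of the 3 values shown sit, compound 4 is expected to show no step beyond the scatter, that is a step that the limit leaves unreadable from compound 3 to compound 4. Compound 4 is estimated at 30000 nM in this assay, with a range from 15000 nM to 80000 nM, most likely reported only as a limit.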

Compound 4, half-maximal cytotoxic concentration: > 20000 nM
Compound 4 ended at the assay's limit; the forecaster's own chance of this, stated with the estimate: 85%; the middle value lies beyond the limit too.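

No step can be read between compound 1, compound 3 and compound 4, because in this assay each gives a limit of the test and not a number: the limit of > 20000 nM in this assay, at which 4 of the 4 values shown sit. The compounds shown leave open at what concentration any of them harms these cells, and whether propylsulfanyl, pyrrolidin-1-yl and propoxy differ at all.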